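The compounds below may be only part of what the source reports. "The series", "measured", "known", "first", "only" and "open" are said of these compounds alone.

- compound 1 `CN(C)c1ccc2[nH]c(Cl)c(/C=C3/C(=O)Nc4ccc(Cl)cc43)c2c1`: 5500 nM
- compound 2 `COc1cc2c(/C=C3/C(=O)N(C)c4ccccc43)c[nH]c2cc1C`: 42700 nM

Both compounds were tested in a functional assay on cells (Cancer cell lines, Homo sapiens) for inhibition, with a stated time of 48 h; a higher number here means a weaker inhibitor of growth, a lower number a stronger inhibitor of growth. Compound 2 holds the higher of the two numbers, which makes it the weaker growth inhibitor, and its gap to compound 1 lies beyond the usual scatter. Compound 3 `COc1cc2c(/C=C3/C(=O)N(C)c4ccc(O)cc43)c[nH]c2cc1C` departs from compound 2 at a single place: hydroxy in place of hydrogen on an aromatic carbon. It carries hydroxy in place of hydrogen on an aromatic carbon. Among the measured compounds shown here, no two measured compounds differ in only one place, so the data give no direct guide to this change. In this assay a small step toward a lower number is expected, and it may not exceed the scatter, with compound 2 at 42700 nM as the only close reference. The estimate amounts to an expected 1.4-fold lower number from compound 2 to compound 3 (0.15 log units; within the scatter). For compound 3 the estimated value is 30000 nM, with an expected range of 10000 nM to 80000 nM.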

Compound 3, concentration for total growth inhibition: 24000 nM
Beside the measured number, compound 3's estimate is 1.3-fold (0.10 log units) above it; the range from low to high includes it.
By their numbers in this assay, from the lowest: compound 1; then compounds 3 and 2 (each within the scatter of the next).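

Among the compounds shown here, this is the first step among the compounds that isolates a single change: in this assay, hydroxy in place of hydrogen on an aromatic carbon of the six-membered aromatic ring of carbon only gives a 1.8-fold lower number from compound 2 to compound 3 (0.25 log units; within the scatter), and that step stays within the scatter. This position therefore accepts a hydroxy group without a shift that this assay can separate from repeat measurement, at least on the core of compound 2. No measurement of any other kind is available to explain this result.

As far as these compounds go, it remains open whether a larger or differently built group at this position, such as a carboxylic acid or a propoxy chain, would move the number beyond the scatter. From the compounds shown here alone, it is also open whether hydroxy here would give a similar step on a core carrying other substituents.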